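Working notes on a small amide-varied series

This account rests on a few compounds, and the source may have more. Where it says the series, first, only, none or still open, it means among the compounds named here.

Measured compounds:
compound 1 `Nc1ccc(Cl)cc1C1=NN(C(=O)c2ccccc2)CC1` — 17%
compound 2 `COc1ccc(N)c(C2=NN(C(=O)c3ccccc3)CC2)c1` — 12.2%
compound 3 `Nc1ccccc1C1=NN(C(=O)c2ccccc2)CC1` — 8.7%

In an assay on isolated protein for inhibition of Nitric oxide synthase, inducible (Homo sapiens), with a stated time of 30 min, tested at 1 mM (a lower number here means less inhibition, a higher number more inhibition at the concentration tested (going by the name of the read-out)), compound 1 holds the highest of the three numbers, yet the steps of a number 4.8 percentage points lower from compound 1 to compound 2 (within the scatter) and a number 8.3 percentage points lower from compound 1 to compound 3 (within the scatter) both lie within the scatter, as does a number 3.5 percentage points lower from compound 2 to compound 3 (within the scatter). Every measured step swaps a group on an aromatic carbon; none touches the carbonyl carbon.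

Compound 4 `CCC(=O)N1CCC(c2cc(Cl)ccc2N)=N1` differs from compound 1 at that carbonyl carbon: ethyl in place of phenyl on a carbonyl carbon. Going by the values given here, no measured step bears on this kind of change, so the three within-scatter steps give no direction, and no movement beyond the scatter is expected. The step of a number 2 percentage points lower from compound 1 to compound 4 (within the scatter) is estimated accordingly. Compound 4 is expected to give about 15%, with a range from 0% to 32%.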

Compound 4, a percentage reported as inhibition, at one concentration (the size of the read-out at that concentration, not a potency): 13.7%
For compound 4 the middle estimate is 1.3 percentage points above the measured one; low and high end bracket the measured number.
By their numbers in this assay, from the lowest: compounds 3, 2, 4 and 1 (each within the scatter of the next).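

Earlier steps covered only groups on an aromatic carbon. In this assay, ethyl in place of phenyl on the carbonyl carbon gives a number 3.3 percentage points lower from compound 1 to compound 4 (within the scatter), so at this position in compound 1 the aromatic ring can be exchanged for a small open chain without a step beyond the scatter. Nothing at hand gives a reason for this result.

As far as these compounds go, whether a longer chain, an amine or a carboxylic acid on the carbonyl carbon would also stay within the scatter remains open. Also open, from the compounds shown here alone, is whether ethyl in place of phenyl gives a similar step in compound 2 or compound 3.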